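Trimming the Ring Amine Substituent from Cyclopentyl to Propyl

This account rests on a few compounds, and the source may have more. Where it says the series, first, only, none or still open, it means among the compounds named here.

Measured compounds:
compound 1, `O=C(CCC1CCN(CC2CCCCC2)CC1)c1ccc2[nH]ccc2c1`: 100%
compound 2, `O=C(CCC1CCN(CC2CCCC2)CC1)c1ccc2[nH]ccc2c1`: 100%

In an assay for displacement of a labelled ligand from 5-hydroxytryptamine receptor 4 (Homo sapiens), with a stated time of 60 min, tested at 1 uM (on this read-out lower numbers stand for less inhibition and higher numbers for more inhibition at the one concentration tested (going by the name of the read-out)), compound 1 gives 100%. Compound 2, which carries a cyclopentyl in place of the cyclohexyl on a saturated chain carbon bound to an amine nitrogen in a ring, gives 100%. The step of no change at the digits printed from compound 1 to compound 2 (within the scatter) is flat, so compound 2 stands level with compound 1 at the digits shown, and both sit at the top of the scale.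

Compound 3, `CCCCN1CCC(CCC(=O)c2ccc3[nH]ccc3c2)CC1`, has not been measured. It differs from compound 2 by propyl in place of cyclopentyl on a saturated chain carbon bound to an amine nitrogen in a ring. Among the compounds with values here, the only measured step that touches this position, no change at the digits printed from compound 1 to compound 2 (within the scatter), swapped one saturated ring for another without any change beyond the scatter. Within the data shown here, replacing the ring with a chain is a different kind of alteration, and no measured pair shows its effect. The step of a number 8 percentage points lower from compound 2 to compound 3 (within the scatter) is therefore expected to be small, with some allowance for a loss. Compound 3 is estimated at 92%, in a range from 70% to 100%.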

Compound 3, a percentage reported as inhibition, at one concentration (the size of the read-out at that concentration, not a potency): 97%
Beside the measured number, compound 3's estimate is 5 percentage points below it, within the range that was stated.
By their numbers in this assay, from the lowest: compounds 3, 1 and 2 (each within the scatter of the next).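

In this assay, the change from a ring to an open chain gives a number 3 percentage points lower from compound 2 to compound 3 (within the scatter), and measured against the cyclohexyl it gives a number 3 percentage points lower from compound 1 to compound 3 (within the scatter). Within the data shown here, the position on a saturated chain carbon bound to an amine nitrogen in a ring therefore accepts propyl as well as cyclopentyl and cyclohexyl at this one concentration, whereas the earlier ring-for-ring step showed only that one saturated ring could replace another. Nothing measured here explains these level numbers.

With all three compounds close to the top of the scale at a single concentration, any differences among them beyond this one read-out cannot be read. On these data alone, it remains open whether a methyl, a benzyl, or a chain ending in an amine or a carboxylic acid would hold the read-out at this position.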